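A few compounds are considered here, and "the series" means these few. Any claim that something is new, unique, unknown or untested is made for them only; others in the source may bear on it.

Compound 3 `COc1ccc(-c2cc3cc(C)ccc3c(-c3cccc(O)c3)n2)c(C)c1` is one of two compounds with a number in an ADME assay on MCF-10A cells (Homo sapiens) for cytotoxicity, read by CCK-8 assay and cell counting, with a stated time of 72 h; on this read-out lower numbers stand for stronger inhibition and higher numbers for weaker inhibition; in this assay compound 3 gives 5050 nM. Compound 2 `COc1cc(OC)cc(-c2cc3ccccc3c(-c3cccc(O)c3)n2)c1` gives 6770 nM in this assay, a number within the scatter of that of compound 3. The third entry is a limit rather than a number: compound 1 `COc1ccc(-c2cc3ccccc3c(-c3ccc(O)cc3)n2)cc1` gives > 50000 nM in this assay (the limit of > 50000 nM in this assay, at which 1 of the 3 values shown sits). Compound 4 `COc1ccc(-c2cc3cc(C)ccc3c(-c3cccc(N)c3)n2)c(C)c1` differs from compound 3 by amino in place of hydroxy on an aromatic carbon. For the measured compounds named here, no measured pair shows this change, so the step from hydroxy to amino is expected to be small, and compound 4 is expected to move from compound 3 by a 1.1-fold higher number from compound 3 to compound 4 (0.04 log units; within the scatter), not beyond the scatter. Compound 4 is estimated at 5500 nM in this assay, with a range from 2500 nM to 15000 nM.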

Compound 4, half-maximal inhibitory concentration: 5740 nM
Estimate against measurement, compound 4: 1.0-fold (0.02 log units) below, and the stated range covers the measured number.
By their numbers in this assay, from the lowest: compounds 3, 4 and 2 (each within the scatter of the next). At a limit, above all of these: compound 1.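

In this assay, for the compounds shown here, replacing 3-hydroxyphenyl with 3-aminophenyl gives a 1.1-fold higher number from compound 3 to compound 4 (0.06 log units; within the scatter) and is the first single-place comparison. Going by these compounds alone, at this position on the ring, amino can stand in for hydroxy without the two compounds being told apart, which the earlier compounds, none differing in only one place, could not show. Nothing measured here gives a reason for this result. On these data alone, whether a carboxylic acid or an amide at this position would stay within the scatter remains open, as does whether the same change would read alike on the core of compound 1.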